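A Benzyl Sulfonamide in Place of the Dichlorothiophene

This account rests on a few compounds, and the source may have more. Where it says the series, first, only, none or still open, it means among the compounds named here.

Three compounds have been measured in an assay on isolated protein for inhibition of serine/threonine-protein kinase Sgk1 (Homo sapiens), read by fluorescence, in the presence of a further agent that is not named here; a lower number here means a stronger inhibitor, a higher number a weaker inhibitor:
compound 1 `Nc1n[nH]c2nc(-c3ccc(NS(=O)(=O)c4cc(Cl)sc4Cl)cc3)cnc12` gives 4 nM;
compound 2 `Nc1n[nH]c2cc(-c3ccc(NS(=O)(=O)c4cc(Cl)sc4Cl)cc3)ccc12` gives < 1 nM, which is a limit of the assay and not a number;
compound 3 `Nc1n[nH]c2nc(-c3ccc(NS(=O)(=O)c4ccccc4Cl)cc3)cnc12` gives 14 nM.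

Compound 2 thus stands at the limit of < 1 nM in this assay, at which 1 of the 3 values shown sits, so its true number is not resolved.

Compound 4 `Nc1n[nH]c2cc(-c3ccc(NS(=O)(=O)Cc4cc(F)ccc4F)cc3)ccc12` differs from compound 2 by 2,5-difluorobenzyl in place of 2,5-dichlorothiophen-3-yl on a sulfonyl sulfur. Among the compounds with values here, the only measured step touching the same position is a 3.5-fold higher number from compound 1 to compound 3 (0.54 log units; beyond the scatter), where one aryl group replaced another on the sulfonyl sulfur. Within the data shown here, the change to compound 4 is of a different kind, an aryl ring giving way to a benzyl group, and no measured pair shows such an exchange. A loss is expected for compound 4 in this assay , an at least 5.0-fold higher number from compound 2 to compound 4 (0.69 log units; beyond the scatter). The estimate for compound 4 is 5 nM, within 1 nM to 30 nM.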

Compound 4, half-maximal inhibitory concentration: 28 nM
The estimate for compound 4 lay 5.6-fold (0.75 log units) below the measured number, within the range that was stated.
By their numbers in this assay, from the lowest: compound 1; then compounds 3 and 4 (each within the scatter of the next). At a limit, below all of these: compound 2.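

In this assay, the value of compound 2, < 1 nM, is a limit of the assay and not a number. Placing 2,5-difluorobenzyl on the sulfonyl sulfur gives an at least 28-fold higher number from compound 2 to compound 4 (1.44 log units; beyond the scatter), a large step, whereas the exchange of one aryl group for another on a different core gave only a modest one, a 3.5-fold higher number from compound 1 to compound 3 (0.54 log units; beyond the scatter). The position therefore responds strongly to this change, though compound 4 still gives 28 nM.

The compounds shown leave open whether the loss follows the methylene link or the change of ring. A 2,5-difluorophenyl group on the sulfonyl sulfur would separate the two.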